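The source may report more compounds than this note shows. Statements on the series, on what has been measured and on what is new or still open speak of the compounds shown alone.

In a functional assay on DU-145 cells (Homo sapiens) for antiproliferative activity, read by propidium iodide staining, with a stated time of 96 h (a higher number here means a weaker inhibitor, a lower number a stronger inhibitor), compound 1 (`CC(O)(CSc1ccc(F)cc1)C(=O)Nc1ccc(S(F)(F)(F)(F)F)cc1`) gives 25400 nM and compound 2 (`CC(O)(COc1ccccc1C(F)(F)F)C(=O)Nc1ccc(S(F)(F)(F)(F)F)cc1`) gives 7100 nM on the same shared core. Compound 3 (`CC(O)(CS(=O)(=O)c1ccc(S(F)(F)(F)(F)F)cc1)C(=O)Nc1ccc(S(F)(F)(F)(F)F)cc1`) reads 28900 nM in this assay and stands level with compound 1, as the gap between those two lies within the usual scatter of repeated measurements. Compound 3 does carry a clearly higher number than compound 2, and that gap lies beyond the scatter.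

Compound 4 (`CC(O)(CS(=O)(=O)c1ccc(OC(F)(F)F)cc1)C(=O)Nc1ccc(S(F)(F)(F)(F)F)cc1`) has not yet been measured. It differs from compound 3 in one place only (a group of 5 heavy atoms (1 carbon, 1 oxygen, 3 fluorine; no ring) in place of a group of 6 heavy atoms (5 fluorine, 1 sulfur; no ring), on an aromatic carbon) and carries a trifluoromethoxy group on an aromatic carbon, para to a large group.

Among the measured compounds shown here, no two measured compounds differ in just one place, so the data give no direct guide to the size of this change. With compound 2 at 7100 nM and compound 3 at 28900 nM in this assay the measured numbers span a modest window, so the expectation is a small move, none beyond the scatter and, if anything, towards a lower number. The expected change is a 1.4-fold lower number from compound 3 to compound 4 (0.16 log units; within the scatter) in this assay as an estimate only. Compound 4 is estimated at 20000 nM with an expected range from 8000 nM to 45000 nM once the measurement is made.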

Compound 4, half-maximal inhibitory concentration: 39300 nM
Compound 4: the middle estimate sits 2.0-fold (0.29 log units) below what was measured, and the stated range covers the measured number.
By their numbers in this assay, from the lowest: compound 2; then compounds 1, 3 and 4 (each within the scatter of the next).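

Among the compounds shown here, this is the first pair here that differs in one place only, so it gives the first direct reading of a single change: in this assay, putting trifluoromethoxy in place of the group of 5 fluorine and 1 sulfur, on an aromatic carbon para to a large group, gives a 1.4-fold higher number from compound 3 to compound 4 (0.13 log units; within the scatter). That step lies within the scatter, so this assay does not tell these two groups apart at this position, and the exchange can be made here without a measurable shift in the number. Nothing measured alongside these compounds offers an explanation for this result.

Going by these compounds, both groups in this pair are fluorine-bearing and have no ring, so it remains open whether a quite different group on this aromatic carbon, such as an amine or a carboxylic acid, would move the number beyond the scatter. Also open is whether the same exchange would read the same way on the other aromatic ring, which keeps the group of 5 fluorine and 1 sulfur in all the compounds shown.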